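Amino in place of nitro on the fused-ring core

The source may hold more compounds than are shown below. What is called first, only, known or untested is meant among the compounds shown, and "the series" means these compounds.

Measured so far:
compound 1 `CS(=O)(=O)NCCN1CCC(CNC(=O)c2cc(Cl)cc3[nH]cnc23)CC1`: an assay on membranes from striatum for binding affinity to 5-hydroxytryptamine receptor 4 (Rattus norvegicus) (on this read-out higher numbers stand for weaker inhibition and lower numbers for stronger inhibition), 0.11 nM
compound 2 `CCCCN1CCC(CNC(=O)c2cc(Cl)c([N+](=O)[O-])c3[nH]cnc23)CC1`: 44.6 nM
compound 3 `CCCCN1CCC(CNC(=O)c2cc(Br)c([N+](=O)[O-])c3[nH]cnc23)CC1`: 48.2 nM

Compound 2 stands second highest of the three numbers. Compound 3 is nearest, a 1.1-fold higher number from compound 2 to compound 3 (0.03 log units; within the scatter), a swap of bromo for chloro. Compound 1 is furthest, with a far lower number, but it differs from compound 2 in more than one place, so only the two values themselves can be set side by side.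

Compound 4 `CCCCN1CCC(CNC(=O)c2cc(Cl)c(N)c3[nH]cnc23)CC1` carries amino in place of nitro on an aromatic carbon. Among the measured compounds shown here, no measured step bears on this change: the only measured step concerns the halogen and leaves the nitro group untouched. Direction must therefore be read loosely from compound 1, which lacks a nitro group altogether and gives 0.11 nM. The estimated step is an 8.9-fold lower number from compound 2 to compound 4 (0.95 log units; beyond the scatter), towards a lower number. Compound 4 is expected at 5 nM, with a range from 0.5 nM to 40 nM.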

Compound 4, inhibition constant: 22.4 nM
Compound 4: middle estimate off by 4.5-fold (0.65 log units), on the low side; measured number inside the range.
By their numbers in this assay, from the lowest: compound 1; then compounds 4, 2 and 3 (each within the scatter of the next, the first and the last beyond it).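

In this assay amino in place of nitro, on the aromatic carbon ortho to a chloro group, gives a 2.0-fold lower number from compound 2 to compound 4 (0.30 log units; within the scatter) and the two compounds read alike. With the butyl chain and chloro group held fixed, this carbon carries either group without a step that stands clear of the scatter. No measured evidence bears on the reason for this result.

From the compounds shown here alone, a hydrogen or a methoxy group on this carbon remains open. Also open, going by these compounds, is how much of the distance to compound 1, which differs in more than one place, belongs to this carbon and how much to the butyl chain.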